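A few compounds are considered here, and "the series" means these few. Any claim that something is new, unique, unknown or untested is made for them only; others in the source may bear on it.

Working notes on the series. In a functional assay on the whole organism for inhibition, with Scenedesmus acutus as the target (on this read-out lower numbers stand for stronger inhibition and higher numbers for weaker inhibition), compound 1 `O=C(O)c1cc(N2C(=O)C3=C(CCCC3)C2=O)c(F)cc1Cl` gives 1000 nM, while compound 2 `C#CCOc1cc(N2C(=O)C3=C(CCCC3)C2=O)ccc1Cl` gives 100 nM. Compound 2 therefore holds the lower of the two numbers, with a gap to compound 1 beyond the scatter.

Compound 3 `C#CCOc1cc(N2C(=O)C3=C(CCCC3)C2=O)c(F)cc1Cl` has not yet been measured. It differs from compound 2 in one place: fluoro in place of hydrogen on an aromatic carbon. This is fluoro in place of hydrogen on an aromatic carbon, para to a propargyloxy group and meta to a chloro group.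

Within the data shown here, no measured pair isolates this change. Compound 1 also carries fluoro, but it differs from compound 2 in more than one place. A modest move toward stronger inhibition is expected in this assay, and a result within the scatter remains possible. The estimated change is a 2.5-fold lower number from compound 2 to compound 3 (0.40 log units; beyond the scatter). For compound 3 the estimated value is 40 nM, with an expected range of 10 nM to 150 nM.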

Compound 3, half-maximal inhibitory concentration: 15.9 nM
Compound 3: middle estimate off by 2.5-fold (0.40 log units), on the high side, within the range that was stated.
By their numbers in this assay, from the lowest: compound 3; then compound 2; then compound 1.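

In this assay, among these compounds, fluoro in place of hydrogen on the aromatic carbon para to a propargyloxy group gives a 6.3-fold lower number from compound 2 to compound 3 (0.80 log units; beyond the scatter) and so provides the first isolated reading of this change, a modest step beyond the scatter. With the fluoro and chloro groups held constant, propargyloxy in place of carboxy gives a 63-fold lower number from compound 1 to compound 3 (1.80 log units; beyond the scatter) as a large step, showing that the series responds strongly to the group at that place as well. No measurement here accounts for either step.

Going by these compounds, each change is read on one background only, so it remains open whether the fluoro step would persist with a methoxy group or a longer chain in place of propargyloxy. The compounds shown also leave open how a nitrile or a second chloro group would compare with fluoro at the same place.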